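A Second Nitro Group on the Amide Ring of Compound 1

The source may hold more compounds than are shown below. What is called first, only, known or untested is meant among the compounds shown, and "the series" means these compounds.

Compound 1 `O=C(Nc1cc(-c2ccccc2)nn1-c1ccccc1)c1cccc([N+](=O)[O-])c1` gives 39 nM in a functional assay on cells for positive allosteric modulation of metabotropic glutamate receptor 5 (Rattus norvegicus), read by calcium flux; a lower number here means that less compound is needed, a higher number that more compound is needed for the effect.
Compound 2 `COc1ccc(C(=O)Nc2cc(-c3ccccc3)nn2-c2ccccc2)cc1` gives 54 nM in this assay.
Compound 3 `O=C(Nc1cc(-c2ccccc2)nn1-c1ccccc1)c1ccc(C(F)(F)F)cc1` gives 38 nM in this assay.

Compound 1 carries the second highest of these three numbers. Its nearest neighbour is compound 3, with a 1.0-fold lower number from compound 1 to compound 3 (0.01 log units; within the scatter), and its furthest is compound 2, with a 1.4-fold higher number from compound 1 to compound 2 (0.14 log units; within the scatter). All three compounds share the same core and differ only in the aromatic ring attached to the carbonyl carbon, and every step among them stays inside the usual scatter.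

The new compound, compound 4 `O=C(Nc1cc(-c2ccccc2)nn1-c1ccccc1)c1cc([N+](=O)[O-])cc([N+](=O)[O-])c1`, arises from compound 1 by a single change: nitro in place of hydrogen on an aromatic carbon. The existing nitro group remains, so the ring now bears two of them.

Neither step measured so far adds a group to the ring of compound 1; both swap the whole ring, and both were small: a 1.4-fold higher number from compound 1 to compound 2 (0.14 log units; within the scatter) and a 1.0-fold lower number from compound 1 to compound 3 (0.01 log units; within the scatter). These steps suggest that this ring tolerates different substituents with little effect in this assay. Among the compounds with values here, no measured compound shows what a second nitro does, so the expectation rests on that tolerance alone.

Compound 4 is therefore expected to sit close to compound 1, a step of a 1.2-fold higher number from compound 1 to compound 4 (0.06 log units; within the scatter) that is not expected to exceed the scatter. The estimate for compound 4 is 45 nM, with a range from 18 nM to 120 nM.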

Compound 4, half-maximal effective concentration: 65 nM
Estimate against measurement, compound 4: 1.4-fold (0.16 log units) below; measured number inside the range.
By their numbers in this assay, from the lowest: compounds 3, 1, 2 and 4 (each within the scatter of the next).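

Within the data shown here, compound 4 is the first compound here in which a group is added to the ring of compound 1 while the original nitro stays in place, whereas the earlier steps exchanged the whole ring. In this assay, placing a nitro on the aromatic carbon that is meta to a large group and meta to a nitro group gives a 1.7-fold higher number from compound 1 to compound 4 (0.22 log units; within the scatter), so this hydrogen can give way to a group of three heavy atoms without a step beyond the scatter. This single comparison extends the earlier picture of a tolerant ring from swapped rings to a ring bearing two nitro groups, but nothing measured explains the size of this step or why the ring accepts the change.

The compounds shown leave open whether this place would accept a different kind of group just as well, such as an amine, a carboxylic acid or a longer chain. They also leave open whether a nitro at this place would give a similar step on a ring that lacks the first nitro.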